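The source may hold more compounds than are shown below. What is called first, only, known or untested is meant among the compounds shown, and "the series" means these compounds.

Three compounds share one core and differ only in the aromatic group attached to it. Compound 1 `C=C1C(=O)[C@]23C[C@@]1(O)CC[C@H]2c1ccc(O)c(C)c1[C@@H]3Cn1cc(-c2ccccn2)nn1` carries pyridin-2-yl there and gives 1570 nM in a functional assay on A549 cells (Homo sapiens) for cytotoxicity, read by MTT assay, with a stated time of 4 days; a higher number here means a weaker inhibitor, a lower number a stronger inhibitor. Compound 2 `C=C1C(=O)[C@]23C[C@@]1(O)CC[C@H]2c1ccc(O)c(C)c1[C@@H]3Cn1cc(-c2ccc(C(F)(F)F)cc2)nn1` carries 4-(trifluoromethyl)phenyl and gives 1110 nM in this assay. Compound 3 `C=C1C(=O)[C@]23C[C@@]1(O)CC[C@H]2c1ccc(O)c(C)c1[C@@H]3Cn1cc(-c2ccc(Cl)cc2)nn1` carries 4-chlorophenyl and gives 640 nM in this assay, the lowest of the three numbers: a 2.5-fold lower number from compound 1 to compound 3 (0.39 log units; beyond the scatter) lies beyond the scatter, whereas a 1.7-fold lower number from compound 2 to compound 3 (0.24 log units; within the scatter) lies within it.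

Compound 4 `C=C1C(=O)[C@]23C[C@@]1(O)CC[C@H]2c1ccc(O)c(C)c1[C@@H]3Cn1cc(-c2ccc(OC)cc2)nn1` differs from compound 3 in one place: methoxy in place of chloro on an aromatic carbon. The step that bears most directly on this change is a 1.7-fold lower number from compound 2 to compound 3 (0.24 log units; within the scatter), since it also exchanged one group on the same aromatic carbon and stayed within the scatter. The moves away from pyridin-2-yl, a 1.4-fold lower number from compound 1 to compound 2 (0.15 log units; within the scatter) and a 2.5-fold lower number from compound 1 to compound 3 (0.39 log units; beyond the scatter), altered the number at most modestly. Nothing measured here shows how methoxy behaves at that position, so no step beyond the scatter is foreseen. The expected step is a 1.4-fold higher number from compound 3 to compound 4 (0.15 log units; within the scatter), small if any. The estimate for compound 4 in this assay is 900 nM, expected to fall between 400 nM and 2000 nM.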

Compound 4, half-maximal inhibitory concentration: 1250 nM
For compound 4 the middle estimate is 1.4-fold (0.14 log units) below the measured one; the measured number falls inside the stated range.
By their numbers in this assay, from the lowest: compounds 3, 2, 4 and 1 (each within the scatter of the next, the first and the last beyond it).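

Methoxy brings oxygen and a hydrogen-bond acceptor to this aromatic carbon, where chloro had neither, yet the number in this assay does not move beyond the scatter (a 2.0-fold higher number from compound 3 to compound 4 (0.29 log units; within the scatter)). Compound 4 also stands within the scatter of the other two compounds (a 1.1-fold higher number from compound 2 to compound 4 (0.05 log units; within the scatter); a 1.3-fold lower number from compound 1 to compound 4 (0.10 log units; within the scatter)), so trifluoromethyl and methoxy cannot be told apart here, and 4-methoxyphenyl cannot be told apart from pyridin-2-yl. Among the compounds shown here, the single step beyond the scatter in this set, from pyridin-2-yl to 4-chlorophenyl, therefore finds no counterpart with 4-methoxyphenyl, and nothing available beyond these numbers bears on the result.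

The compounds shown leave open whether a group of another kind on this aromatic carbon, such as an amine, a carboxylic acid or a longer chain like butoxy, would carry the number outside the narrow band seen so far. They also leave open whether chloro or methoxy would give the same picture at another carbon of that ring, since each group appears here in only one place.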